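This account rests on a few compounds, and the source may have more. Where it says the series, first, only, none or still open, it means among the compounds named here.

Compound 1, `CCC(C)C(N)c1cc(C(F)(F)F)ccc1N1CCN(C(=O)CCc2ccc(Cl)cc2Cl)CC1`, gives 160 nM in an assay on HEK293 cells for displacement of a labelled ligand from Melanocortin receptor 4 (Homo sapiens); a higher number here means a weaker inhibitor, a lower number a stronger inhibitor.
Compound 2, `CCC(C)[C@H](N)c1cc(C(F)(F)F)ccc1N1CCN(C(=O)CCc2ccc(OC)cc2Cl)CC1`, gives 57 nM in this assay.
Compound 3, `CC(C)C[C@H](N)c1cc(C(F)(F)F)ccc1N1CCN(C(=O)CCc2ccc(S(C)(=O)=O)cc2)CC1`, gives 4900 nM in this assay.

Among these three numbers compound 1 stands second highest. Compound 2 gives a lower number than compound 1, and the gap between them lies beyond the usual scatter of repeated measurements. Compound 3 gives a much higher number than compound 1, also beyond the scatter. Compound 4, `CCC(C)[C@H](NC(=O)CN)c1cc(C(F)(F)F)ccc1N1CCN(C(=O)CCc2ccc(Cl)cc2Cl)CC1`, has not yet been measured in this assay. It is built from compound 1 by one change: 1-(((aminomethyl)carbonyl)amino)-2-methylbutyl in place of 1-amino-2-methylbutyl on an aromatic carbon. The rest of the shared core is kept as it stands in compound 1. For the measured compounds named here, no pair among the measured compounds differs in only this place, so nothing measured shows directly what such a change does here. A step in this assay towards a somewhat higher number is expected, modest in size and possibly no larger than the scatter. The step from compound 1 to compound 4 is therefore expected to be a 2.0-fold higher number from compound 1 to compound 4 (0.30 log units; within the scatter). Compound 4 is estimated to give 320 nM, with a range from 60 nM to 1700 nM.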

Compound 4, inhibition constant: 18 nM
The estimate for compound 4 lay 18-fold (1.25 log units) above the measured number; the measured number lies below the stated range.
By their numbers in this assay, from the lowest: compound 4; then compound 2; then compound 1; then compound 3.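

In this assay, putting 1-(((aminomethyl)carbonyl)amino)-2-methylbutyl in place of 1-amino-2-methylbutyl on the aromatic carbon gives an 8.9-fold lower number from compound 1 to compound 4 (0.95 log units; beyond the scatter). The earlier compounds shown here all carry a free amine on this side chain, so they could not show that this place tolerates a larger group, nor that turning this amine into an amide can lower the number. Nothing here gives a measured reason for the step.

As far as these compounds go, what remains open is which part of the added group matters: a plain acetyl group on the same nitrogen, or a longer chain such as 3-aminopropanoyl, would test the amide and the end amine separately. The entering group also has a defined stereocentre, so a single-isomer form of compound 1 would be needed to show how much of the step comes from the new group alone.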